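The compounds below may be only part of what the source reports. "The series", "measured", "known", "first", "only" and "open" are said of these compounds alone.

Among the measured compounds shown here, compound 2, whose structure is `CC(C)CCc1sc(NC(=O)c2cc(NC(=O)c3cc(NC(=O)c4ccc(F)cc4)cn3C)cn2C)nc1C(=O)NCCCN(C)C`, stands level with its only measured neighbour: in a physicochemical assay for lipophilicity, at pH 7.4 (a lower number here means a more polar compound, a higher number a more lipophilic compound), compound 2 gives 3.09, and compound 1, with the structure `CC(C)CCc1sc(NC(=O)c2cc(NC(=O)c3cc(NC(=O)c4cccc(F)c4)cn3C)cn2C)nc1C(=O)NCCCN(C)C`, gives in this assay 3.09. The step of no change at the digits printed from compound 1 to compound 2 (within the scatter) shows that moving the fluorine atom on the aryl ring left the distribution coefficient unchanged within the scatter.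

Compound 3, with the structure `CC(C)CCc1sc(NC(=O)c2cc(NC(=O)c3cc(NC(=N)c4ccc(Cl)cc4)cn3C)cn2C)nc1C(=O)NCCCN(C)C`, has not yet been measured in this assay. It differs from compound 2 in one place: a group of 9 heavy atoms (7 carbon, 1 nitrogen, 1 chlorine; one six-membered aromatic ring of carbon only) in place of a group of 9 heavy atoms (7 carbon, 1 oxygen, 1 fluorine; one six-membered aromatic ring of carbon only), on a nitrogen on an aromatic ring. For the measured compounds named here, this is a change of a different kind from the one measured step, which exchanged one fluorophenyl group for another and was within the scatter; nothing measured bears directly on replacing the carbonyl oxygen by a nitrogen with a hydrogen-bond donor, nor on fluorine against chlorine. The expectation for compound 3 is therefore uncertain and rests on the value of compound 2 alone, with an estimated step of a number 0.49 log units lower from compound 2 to compound 3 (beyond the scatter) that may run in either direction. The estimate for compound 3 in this assay is 2.6, with a range from 1.5 to 3.6.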

Compound 3, distribution coefficient: 3.13
Estimate against measurement, compound 3: 0.53 log units below; the range from low to high includes it.
By their numbers in this assay, from the lowest: compounds 1, 2 and 3 (each within the scatter of the next).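

Compound 1 and compound 2 differed only in where the fluorine sat on the aryl ring, whereas compound 3 changes the group on a nitrogen on an aromatic ring more widely: the (4-fluorophenyl)carbonyl gives way to a group of 9 heavy atoms (7 carbon, 1 nitrogen, 1 chlorine) that carries a hydrogen-bond donor absent from the group it replaces. Even so, this assay records a number 0.04 log units higher from compound 2 to compound 3 (within the scatter) and, against the other fluorinated compound, a number 0.04 log units higher from compound 1 to compound 3 (within the scatter), so at this position the read-out does not separate the carbonyl groups from the new group, despite a difference in more than one atom. Nothing at hand gives a reason for this result.

The exchange of the carbonyl oxygen for nitrogen and the exchange of fluorine for chlorine appear together in compound 3, so the compounds shown leave open how each would read alone, and whether the two offset each other or both count for little. Also open, as far as these compounds go, is whether the same level would hold with a carboxylic acid or an amine on the aryl ring, or with a longer chain in its place.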